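From Heptyl to Isopropyl: Expected Cytotoxicity of Compound 3

The source may hold more compounds than are shown below. What is called first, only, known or untested is meant among the compounds shown, and "the series" means these compounds.

Compound 1, `CCCCCCCc1c(C)[nH]c2cc(OC)c(Cl)cc2c1=O`: in an ADME assay on J774 cells (Mus musculus) for cytotoxicity (a lower number here means that less compound is needed, a higher number that more compound is needed for the effect), compound 1 gives > 37100 nM, a limit of the assay rather than a number.
Compound 2, `CCCCCCCCCc1c(C)[nH]c2cc(OC)c(Cl)cc2c1=O`: in this assay compound 2 gives > 28700 nM, again a limit of the assay.

Compound 1 thus stands only at a limit in this assay, its value sitting at the limit of > 37100 nM in this assay, at which 1 of the 2 values shown sits. Compound 2 sits at the limit of > 28700 nM in this assay, at which 1 of the 2 values shown sits. Within the data shown here, the one measured step, a step that the two limits leave unreadable from compound 1 to compound 2, is therefore of no readable size.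

Compound 3, `COc1cc2[nH]c(C)c(C(C)C)c(=O)c2cc1Cl`, differs from compound 1 by isopropyl in place of heptyl on an aromatic carbon. Among the measured compounds shown here, no measured step covers this change; the single comparison available concerns a longer chain and gives no direction or size. Because compound 1 sits at the limit of > 37100 nM in this assay, at which 1 of the 2 values shown sits, compound 3 is expected to remain at or beyond the limit as well, so the step that the limit leaves unreadable from compound 1 to compound 3 is expected to be none beyond the scatter. Compound 3 is estimated at 40000 nM, with a range from 15000 nM to 110000 nM.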

Compound 3, half-maximal effective concentration: 21700 nM
The estimate for compound 3 lay 1.8-fold (0.27 log units) above the measured number, within the range that was stated.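

In this assay, among these compounds, compound 3 is the only one of the three compounds that gives a number rather than a limit, which shows that a measurable effect can be reached with this core when isopropyl replaces heptyl on this aromatic carbon. The change gives an at least 1.7-fold lower number from compound 1 to compound 3 (0.23 log units; that floor lies within the scatter) as its one readable result, so it cannot be said to lower the number by more than the usual scatter. Compound 1 still gives only a limit of the assay, which sets the true size of the step out of reach: the limit of > 37100 nM in this assay, at which 1 of the 3 values shown sits.

The compounds shown leave open whether chain length or branching matters here, since heptyl and isopropyl differ in both, and a straight propyl chain would separate the two. They also leave open how an amine or a carboxylic acid at this carbon would behave.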